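The source may hold more compounds than are shown below. What is called first, only, known or untested is meant among the compounds shown, and "the series" means these compounds.

In a functional assay on A549 cells (Homo sapiens) for antiproliferative activity, read by spectrophotometry, with a stated time of 2 days (a lower number here means a stronger inhibitor of growth, a higher number a weaker inhibitor of growth), compound 3 (`Cc1cc(F)ccc1Nc1ncc(C(F)(F)F)c(N2Cc3cccc(N(C)S(C)(=O)=O)c3C2)n1`) gives > 30000 nM as its result, which is a limit of the assay and not a number. On the same core, compound 1 (`CC(=O)N1CCN(c2ccc(Nc3ncc(C(F)(F)F)c(N4Cc5cccc(N(C)S(C)(=O)=O)c5C4)n3)cc2)CC1`) gives 1300 nM and compound 2 (`CN(c1cccc2c1CN(c1nc(Nc3ccc(Nc4ccccc4)cc3)ncc1C(F)(F)F)C2)S(C)(=O)=O`) gives 6200 nM in this assay as well. Compound 4 (`COc1cc(Nc2ncc(C(F)(F)F)c(N3Cc4cccc(N(C)S(C)(=O)=O)c4C3)n2)cc(C(F)(F)F)c1`) has 3-methoxy-5-(trifluoromethyl)phenyl in place of 4-fluoro-2-methylphenyl on a nitrogen on an aromatic ring, and the count of that change is 3-methoxy-5-(trifluoromethyl)phenyl in place of 4-fluoro-2-methylphenyl on a nitrogen on an aromatic ring. Among the compounds with values here, the one measured step, a 4.8-fold higher number from compound 1 to compound 2 (0.68 log units; beyond the scatter), has anilino in place of 4-acetylpiperazin-1-yl on an aromatic carbon. It is modest but beyond the scatter. It is also a different change from the one at hand, so it bears only loosely, as a gauge of how far a single swap of groups has moved the number in these compounds. Within the data shown here, no measured step starts from compound 3. Taking the size of a 4.8-fold higher number from compound 1 to compound 2 (0.68 log units; beyond the scatter) as the gauge for compound 4, a modest move toward a lower number in this assay is expected, though a result that again reaches the limit is about as likely. The expected size is an at least 1.7-fold lower number from compound 3 to compound 4 (0.24 log units; that floor lies within the scatter) on this estimate. For compound 4 the estimate is 17000 nM, with an expected range from 6000 nM to 30000 nM.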

Compound 4, concentration for 50% growth inhibition: > 30000 nM
Compound 4 was reported as a limit; the forecaster's own chance of this, stated with the estimate: 50%; middle value at least 1.7-fold (0.24 log units) from the limit.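

Compound 3 and compound 4 both sit at a limit of this assay and not at a number, so no step between them can be read: the limit of > 30000 nM in this assay, at which 2 of the 4 values shown sit.

The compounds shown leave open whether 3-methoxy-5-(trifluoromethyl)phenyl in place of 4-fluoro-2-methylphenyl moves the result in this assay at all, and in which direction.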